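The source may report more compounds than this note shows. Statements on the series, on what has been measured and on what is new or still open speak of the compounds shown alone.

In a functional assay on MCF7 cells (Homo sapiens) for antiproliferative activity, read by sulforhodamine B assay, with a stated time of 48 h, tested at 50 uM (a higher number here means more inhibition at the concentration tested (going by the name of the read-out), a lower number less inhibition), compound 2, with structure `CC1=CC[C@H](C(C)C)c2cc(C)c(OC(=O)c3cccc(C)c3)cc21`, gives 54.9%, the second highest of the three numbers shown. For the measured compounds named here, compound 1 `Cc1cc2c(C(C)C)ccc(C)c2cc1OC(=O)c1cccc(C(F)(F)F)c1` gives 41.5%, and compound 3 `CC1=CC[C@H](C(C)C)c2cc(C)c(OC(=O)c3cccc(C(F)(F)F)c3)cc21` gives 86%; the step of a number 31.1 percentage points higher from compound 2 to compound 3 (beyond the scatter) is the only measured step between two compounds that differ in one place. Compound 4 `CC1=CC[C@H](C(C)C)c2cc(C)c(OC(=O)Nc3ccccc3)cc21` differs from compound 2 at the carbonyl carbon: anilino in place of 3-methylphenyl on a carbonyl carbon. Going by the values given here, no measured step changes the ester to a carbamate, so the step from compound 2 to compound 3 does not bear on this change directly; it only shows that a single change at this side of the molecule can move the read-out far. With nothing comparable to lean on, compound 4 is expected to stay near compound 2, an estimated step of a number 4.9 percentage points lower from compound 2 to compound 4 (within the scatter) within the scatter but with a wide margin. Compound 4 is therefore estimated at 50%, between 25% and 78%.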

Compound 4, a percentage reported as inhibition, at one concentration (the size of the read-out at that concentration, not a potency): 75.1%
Estimate against measurement, compound 4: 25.1 percentage points below, and the stated range covers the measured number.
By their numbers in this assay, from the lowest: compound 1; then compound 2; then compound 4; then compound 3.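

Anilino in place of 3-methylphenyl on a carbonyl carbon gives a number 20.2 percentage points higher from compound 2 to compound 4 (beyond the scatter) in this assay. This shows that the read-out responds to replacing the whole group on the carbonyl carbon, turning the ester into a carbamate, and not only to changing a substituent on the aromatic ring. Nothing measured here explains the rise.

As far as these compounds go, whether the rise depends on the amide hydrogen stays open, and an N-methylanilino group would address that. From the compounds shown here alone, it is also open whether a non-aromatic group such as cyclohexylamino would give a similar number.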